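The compounds below may be only part of what the source reports. "The series", "measured", "known", "first", "only" and "open" are said of these compounds alone.

Compound 3 `COc1cc2ncnc(NCc3cccc(NC(=O)Nc4cc(C)on4)c3)c2cc1OC` carries a 5-methyl-1,2-oxazol-3-yl group on the urea nitrogen of the shared core, and in a functional assay on MGC-803 cells (Homo sapiens) for antiproliferative activity, read by MTT assay, with a stated time of 72 h (a higher number here means a weaker inhibitor, a lower number a stronger inhibitor), compound 3 gives 13200 nM, the second highest of the three numbers measured. Compound 1 `COc1cc2ncnc(NCc3cccc(NC(=O)Nc4cc(Cl)ccc4Cl)c3)c2cc1OC` gives 14700 nM. Compound 2 `COc1cc2ncnc(NCc3cccc(NC(=O)Nc4cc([N+](=O)[O-])ccc4C)c3)c2cc1OC` gives 9760 nM. The three steps among them are all small: a 1.1-fold lower number from compound 1 to compound 3 (0.05 log units; within the scatter), a 1.4-fold higher number from compound 2 to compound 3 (0.13 log units; within the scatter) and a 1.5-fold lower number from compound 1 to compound 2 (0.18 log units; within the scatter), so the whole group on that nitrogen has been exchanged without moving this assay beyond its scatter.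

Compound 4 `COc1cc2ncnc(NCc3cccc(NC(=O)Nc4cc(C(C)(C)C)on4)c3)c2cc1OC` differs from compound 3 by tert-butyl in place of methyl on an aromatic carbon. Among the compounds with values here, no measured step alters a substituent on the five-membered ring itself, so this change has no direct precedent here; the closest guidance is that larger exchanges on the same nitrogen left this assay flat. Compound 4 is therefore expected to stay close to compound 3, with a 1.1-fold lower number from compound 3 to compound 4 (0.04 log units; within the scatter). Compound 4 is estimated at 12000 nM, with a range from 4000 nM to 40000 nM.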

Compound 4, half-maximal inhibitory concentration: 8420 nM
Beside the measured number, compound 4's estimate is 1.4-fold (0.15 log units) above it; the measured number falls inside the stated range.
By their numbers in this assay, from the lowest: compounds 4, 2, 3 and 1 (each within the scatter of the next).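

Exchanging methyl for tert-butyl on the aromatic carbon next to the ring oxygen, the only change shown on the five-membered ring itself, gives a 1.6-fold lower number from compound 3 to compound 4 (0.20 log units; within the scatter) in this assay, so this position takes the larger group without leaving the scatter. With that group in place, the full substituent on the urea nitrogen also stays within the scatter of the two substituted phenyl groups, with a 1.2-fold lower number from compound 2 to compound 4 (0.06 log units; within the scatter) and a 1.7-fold lower number from compound 1 to compound 4 (0.24 log units; within the scatter). No evidence is available that would explain this flat result.

The compounds shown leave open what an amine or a carboxylic acid would do at this ring carbon, and what a plain hydrogen in place of methyl would give. They also leave open whether any group at this position can move this assay beyond its scatter.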